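Swapping a methoxyphenyl for a thiophene on a sulfonamide core

The compounds below may be only part of what the source reports. "The series", "measured", "known", "first", "only" and "open" are said of these compounds alone.

Of the compounds shown here, three sharing one core have been measured in a functional assay on NCI-H460 cells (Homo sapiens) for inhibition, with a stated time of 72 h; a lower number here means a stronger inhibitor, a higher number a weaker inhibitor. Compound 1 `COc1ccc(S(=O)(=O)N2CCc3cccc(-c4ccc(F)cc4)c32)cc1` gives 95.5 nM, compound 2 `COc1ccc(S(=O)(=O)N2CCc3cccc(-c4ccc(O)cc4)c32)cc1` gives 114 nM, and compound 3 `COc1ccc(-c2cccc3c2N(S(=O)(=O)c2ccc(OC)cc2)CC3)cc1` gives 302 nM, the highest of the three numbers. The step of a 3.2-fold higher number from compound 1 to compound 3 (0.50 log units; beyond the scatter) and the step of a 2.6-fold higher number from compound 2 to compound 3 (0.42 log units; beyond the scatter) both reach beyond the scatter, while the step of a 1.2-fold higher number from compound 1 to compound 2 (0.08 log units; within the scatter) stays within it. Compound 4 `COc1ccc(S(=O)(=O)N2CCc3cccc(-c4cccs4)c32)cc1` differs from compound 3 in one place: thiophen-2-yl in place of 4-methoxyphenyl on an aromatic carbon. Among the measured compounds shown here, no measured step exchanges one whole ring for another, so the nearest guidance comes from the two steps that lead into compound 3, in which adding the methoxy group went with a modestly higher number. Taking that group away again is therefore expected to give a modestly lower number, roughly a return to the level of compound 1 and compound 2, as the step of a 2.5-fold lower number from compound 3 to compound 4 (0.40 log units; beyond the scatter) expresses. The estimate for compound 4 is 120 nM, within a range from 50 nM to 300 nM.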

Compound 4, half-maximal inhibitory concentration: 229 nM
Compound 4: the middle estimate sits 1.9-fold (0.28 log units) below what was measured, within the range that was stated.
By their numbers in this assay, from the lowest: compounds 1, 2, 4 and 3 (each within the scatter of the next, the first and the last beyond it).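

In this assay, among the compounds shown here, this is the first change of the whole ring rather than of a group carried on it, and the numbers barely separate the two rings: a 1.3-fold lower number from compound 3 to compound 4 (0.12 log units; within the scatter) and a 2.0-fold higher number from compound 2 to compound 4 (0.30 log units; within the scatter) both stay within the scatter. Only the comparison with the 4-fluorophenyl ring reaches beyond it, as a 2.4-fold higher number from compound 1 to compound 4 (0.38 log units; beyond the scatter), and that step is modest. So this place, ortho to a fused ring, accepts a five-membered aromatic ring with a sulfur atom as well as a six-membered carbon ring, at a cost that shows against only one of the three earlier compounds.

Nothing shown gives a reason for these steps. As far as these compounds go, it remains open whether an amine or a carboxylic acid carried on the thiophene ring would move the number at all.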